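The source may hold more compounds than are shown below. What is called first, only, known or untested is meant among the compounds shown, and "the series" means these compounds.

Three compounds were measured in a functional assay on HT-29 cells (Homo sapiens) for antiproliferative activity, read by MTT assay, with a stated time of 72 h; on this read-out lower numbers stand for stronger inhibition and higher numbers for weaker inhibition:

Compound 1 `COc1ccc(-n2c(=O)c(C(=O)Nc3ccc(Oc4ccnc5[nH]ccc45)cc3)cc3cccnc32)cc1`: 1260 nM
Compound 2 `O=C(Nc1ccc(Oc2ccnc3[nH]ccc23)cc1)c1cc2cccnc2n(-c2ccc(F)c(Cl)c2)c1=O`: 560 nM
Compound 3 `COc1ccc(-n2c(=O)c(C(=O)Nc3ccc(Oc4ccnc5c4ccn5C)c(F)c3)cc3cccnc32)cc1`: 1290 nM

Compound 1 and compound 2 share a core and differ by one change, (3-chloro-4-fluorophenyl in place of 4-methoxyphenyl on an aromatic nitrogen). This change made a 2.3-fold lower number from compound 1 to compound 2 (0.35 log units; beyond the scatter). Compound 3 carries a different core; the difference between the two cores is not broken down here, and the values of compound 1 and compound 3 lie within the usual scatter of each other.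

Compound 4 `Cn1ccc2c(Oc3ccc(NC(=O)c4cc5cccnc5n(-c5ccc(F)c(Cl)c5)c4=O)cc3F)ccnc21` has not yet been measured. It differs from compound 3 by 3-chloro-4-fluorophenyl in place of 4-methoxyphenyl on an aromatic nitrogen, the same change as between compound 1 and compound 2. The step from compound 3 to compound 4 in this assay is expected to be a 2.3-fold lower number from compound 3 to compound 4 (0.36 log units; beyond the scatter), because the earlier step was a 2.3-fold lower number from compound 1 to compound 2 (0.35 log units; beyond the scatter). Compound 4 is therefore estimated at 560 nM, with a likely range from 250 nM to 1300 nM.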

Compound 4, half-maximal inhibitory concentration: 2460 nM
Compound 4: middle estimate off by 4.4-fold (0.64 log units), on the low side; measured number outside the range, above it.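

In this assay, putting 3-chloro-4-fluorophenyl in place of 4-methoxyphenyl on the core of compound 3 gives a 1.9-fold higher number from compound 3 to compound 4 (0.28 log units; within the scatter), so the gain seen on the core of compound 1 does not reappear. The two steps differ by more than repeat measurements would account for, so the result of this change did not carry over from one core to the other: the same change on two cores in this assay, a 2.3-fold lower number (0.35 log units; beyond the scatter) from compound 1 to compound 2 and a 1.9-fold higher number (0.28 log units; within the scatter) from compound 3 to compound 4, 4.3-fold (0.63 log units) apart, beyond the scatter of two such steps. This shows that the change depends on its core for these two cores, but it does not show which feature of the cores is responsible or how the change would behave on a third core.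

The compounds shown leave open which part of the difference between the two cores matters. Also open, going by these compounds, is how another group on that aromatic nitrogen, such as a phenyl ring carrying an amine, would behave on either core.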